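N-Methylation of the azaindole in the fluorinated pair

The source may report more compounds than this note shows. Statements on the series, on what has been measured and on what is new or still open speak of the compounds shown alone.

Compound 1 `O=C(Nc1ccc(Oc2ccnc3[nH]ccc23)c(F)c1)c1cc2cccnc2n(-c2ccc(Br)cc2)c1=O` is the reference point of this set: in a functional assay on U-87MG ATCC cells for antiproliferative activity against U-87 MG (Homo sapiens), read by MTT assay, with a stated time of 72 h (on this read-out higher numbers stand for weaker inhibition and lower numbers for stronger inhibition), compound 1 gives 1510 nM. Compound 2 `O=C(Nc1ccc(Oc2ccnc3[nH]ccc23)c(F)c1)c1cc2cccnc2n(-c2ccc(Br)cc2F)c1=O` carries an additional fluorine on the bromophenyl ring relative to compound 1, but in this assay compound 2 gives "not determined" (no result reported), so compound 2 stands nowhere on the measured scale, and the only anchor for the series is compound 1.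

Compound 3 `Cn1ccc2c(Oc3ccc(NC(=O)c4cc5cccnc5n(-c5ccc(Br)cc5F)c4=O)cc3F)ccnc21` is the next member. It differs from compound 2 by methyl in place of hydrogen on an aromatic nitrogen. Among the measured compounds shown here, no measured step covers this change anywhere in the set, so the size and direction of the effect in this assay cannot be read from the data; the expectation rests only on compound 1 as the sole measured analogue.

Compound 3 is estimated to give 4000 nM in this assay, with a plausible range from 900 nM to 18000 nM, an expectation that leans toward weaker inhibition than the value of compound 1.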

Compound 3, half-maximal inhibitory concentration: 6470 nM
For compound 3 the middle estimate is 1.6-fold (0.21 log units) below the measured one, and the stated range covers the measured number.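

No new step can be read: compound 3, at 6470 nM in this assay, differs in one place only from compound 2, which has no single number there. The compounds shown leave open what methyl in place of hydrogen on an aromatic nitrogen does on its own to this read-out. No supporting evidence bears on this result.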